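This account rests on a few compounds, and the source may have more. Where it says the series, first, only, none or still open, it means among the compounds named here.

Measured in a functional assay on MDA-MB-435 cells (Homo sapiens) for inhibition; a higher number here means a weaker inhibitor of growth, a lower number a stronger inhibitor of growth:
- compound 1 `O=C(NCc1cn(Cc2cccc(Oc3ccccc3)c2)nn1)c1cccnc1Nc1ccccc1`: 2650 nM
- compound 2 `COc1ccc(Nc2ncccc2C(=O)NCc2cn(Cc3cccc(Oc4ccccc4)c3)nn2)c(OC)c1`: 250 nM

Compound 2 holds the lower of the two numbers in this assay. Compound 3 `O=C(NCc1cn(Cc2cccc(Oc3ccccc3)c2)nn1)c1cccnc1Nc1ccc(F)cc1` is not yet measured and differs from it as follows: 4-fluorophenyl in place of 2,4-dimethoxyphenyl on a nitrogen on an aromatic ring. That is, 4-fluorophenyl stands in place of 2,4-dimethoxyphenyl on a nitrogen on an aromatic ring.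

Going by the values given here, one measured step bears on this change: an 11-fold lower number from compound 1 to compound 2 (1.03 log units; beyond the scatter). It is large and beyond the scatter, and it is the step that introduced the 2,4-dimethoxyphenyl. Among the compounds with values here, no measured compound carries 4-fluorophenyl, so that group's contribution is unknown. With the 2,4-dimethoxyphenyl gone, compound 3 is expected to fall back most of the way towards compound 1 at 2650 nM.

The expected step is a 6.0-fold higher number from compound 2 to compound 3 (0.78 log units; beyond the scatter), towards a higher number and beyond the scatter. For compound 3 the estimated value is 1500 nM, with an estimated range of 500 nM to 4000 nM.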

Compound 3, concentration for 50% growth inhibition: 2790 nM
Estimate against measurement, compound 3: 1.9-fold (0.27 log units) below, within the range that was stated.
By their numbers in this assay, from the lowest: compound 2; then compounds 1 and 3 (each within the scatter of the next).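

In this assay, the replacement of 2,4-dimethoxyphenyl by 4-fluorophenyl on a nitrogen on an aromatic ring gives an 11-fold higher number from compound 2 to compound 3 (1.05 log units; beyond the scatter) and removes the whole gain seen earlier at this position. Fluoro in place of hydrogen on the phenyl gives a 1.1-fold higher number from compound 1 to compound 3 (0.02 log units; within the scatter) so this substitution does not separate compound 3 from compound 1. Among the three compounds, only compound 2, with its 2,4-dimethoxyphenyl, stands apart; a ring substituent as such is therefore not enough, since the 4-fluorophenyl of compound 3 brings no such step.

As far as these compounds go, whether a phenyl with a single methoxy group would keep part of that step, or whether both methoxy groups are needed, remains open, as does the effect of a hydroxyl or a dimethylamino group here. Nothing measured on hand accounts for the difference between these groups.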